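Swapping Chloro for Amino: What the Cells May Show

A few compounds are considered here, and "the series" means these few. Any claim that something is new, unique, unknown or untested is made for them only; others in the source may bear on it.

Compound 1 `ClCc1ccccc1Cn1cnc2c(Cl)nc(Cl)nc21` and compound 2 `ClCc1cccc(Cn2cnc3c(Cl)nc(Cl)nc32)c1` are built from the same atoms joined differently; the difference between the two cores is not broken down here. In a functional assay on T47D cells (Homo sapiens) for cytotoxicity, read by sulforhodamine B assay, with a stated time of 48 h (on this read-out lower numbers stand for stronger inhibition of growth and higher numbers for weaker inhibition of growth), compound 1 gives 1990 nM, and compound 2 gives 1950 nM, two values within the usual scatter of each other. Compound 3 `Nc1nc(Cl)c2ncn(Cc3ccccc3CCl)c2n1` is compound 1 with amino in place of chloro on an aromatic carbon; in this assay compound 3 gives 24000 nM, a step of a 12-fold higher number from compound 1 to compound 3 (1.08 log units; beyond the scatter). Compound 4 `Nc1nc(Cl)c2ncn(Cc3cccc(CCl)c3)c2n1` is compound 2 with the same change at the same place, (amino in place of chloro on an aromatic carbon), and has not yet been measured. For the measured compounds named here, because the only measured example of this change is a 12-fold higher number from compound 1 to compound 3 (1.08 log units; beyond the scatter), the expected step is a 12-fold higher number from compound 2 to compound 4 (1.07 log units; beyond the scatter) in this assay. Compound 4 is therefore estimated at 23000 nM, most likely between 11000 nM and 48000 nM.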

Compound 4, concentration for 50% growth inhibition: 6020 nM
Beside the measured number, compound 4's estimate is 3.8-fold (0.58 log units) above it, and the stated range ends above it.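

In this assay, the step of a 3.1-fold higher number from compound 2 to compound 4 (0.49 log units; beyond the scatter) means that amino in place of chloro on an aromatic carbon weakens growth inhibition on this core too, so the direction of the change carries over. Its size does not carry over, and the two steps differ by more than repeat measurements would explain: the same change on two cores in this assay, a 12-fold higher number (1.08 log units; beyond the scatter) from compound 1 to compound 3 and a 3.1-fold higher number (0.49 log units; beyond the scatter) from compound 2 to compound 4, 3.9-fold (0.59 log units) apart, beyond the scatter of two such steps. With only these two pairs, the data do not show how large the step would be on a further core, or why its size differs between these two.

From the compounds shown here alone, it remains open whether a methoxy group or a methylamino group on that same aromatic carbon would give a number closer to compound 2 or to compound 4. Going by these compounds, whether amino would weaken growth inhibition on other cores also remains open.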